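This account rests on a few compounds, and the source may have more. Where it says the series, first, only, none or still open, it means among the compounds named here.

Measured compounds:
compound 1, `COc1cc(C)cc(-c2c(-c3ccnc(-c4ccc(C(C)=O)cc4)c3)cnn2CC#N)c1`: 19%
compound 2, `Cc1cc(O)cc(-c2nn(CC#N)cc2-c2ccnc(-c3ccc(Oc4ccccc4)cc3)c2)c1`: -91%
compound 3, `COc1cc(C)cc(-c2nn(CC#N)cc2-c2ccnc(-c3ccc(N(C)C)cc3)c2)c1`: 5%

In a functional assay on LOX IMVI cells (Homo sapiens) for cytotoxicity, read by sulforhodamine B assay, with a stated time of 48 h, tested at 1 uM (on this read-out higher numbers stand for a weaker effect at the one concentration tested and lower numbers for a stronger effect), compound 1 gives 19%, the highest of the three numbers. Its nearest neighbour is compound 3, whose number lies below it by more than the scatter, and compound 2 lies far below both. The unmeasured compound is compound 4, `COc1cc(C)cc(-c2c(-c3ccnc(-c4ccc(N(C)C)cc4)c3)cnn2CC#N)c1`. It differs from compound 1 in one place: dimethylamino in place of acetyl on an aromatic carbon. Within the data shown here, no measured pair shows this exchange alone, so the expectation rests on compound 3, which carries the dimethylamino group on a related core and gives 5%. The step is expected to be a slight lowering, a number 9 percentage points lower from compound 1 to compound 4 (within the scatter), staying within the scatter. Compound 4 is estimated at 10%, with a range from -25% to 35%.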

Compound 4, a percentage reported as activity, at one concentration (the size of the read-out at that concentration, not a potency): 12%
Compound 4: the middle estimate sits 2 percentage points below what was measured; low and high end bracket the measured number.
By their numbers in this assay, from the lowest: compound 2; then compounds 3, 4 and 1 (each within the scatter of the next, the first and the last beyond it).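

Among these compounds, with the core held fixed, this is the first direct reading of the exchange at this aromatic carbon, para to a large group: in this assay, going from 4-acetylphenyl to 4-(dimethylamino)phenyl gives a number 7 percentage points lower from compound 1 to compound 4 (within the scatter). At this one concentration, the two groups therefore cannot be told apart on this position. Nothing available bears on why this is so.
Going by these compounds, whether a carboxylic acid, a primary amine or a longer alkyl chain at the same place would give a step beyond the scatter remains open. So does whether this exchange behaves alike on any other core.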